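A few compounds are considered here, and "the series" means these few. Any claim that something is new, unique, unknown or untested is made for them only; others in the source may bear on it.

In a physicochemical assay for lipophilicity (on this read-out higher numbers stand for higher lipophilicity and lower numbers for lower lipophilicity), compound 1 `Cc1cc(-c2noc([C@H](C)NC(=O)c3cc(C(F)(F)F)nn3C)n2)ccn1` gives 3.3 and compound 2 `C[C@H](NC(=O)c1cc(C(F)(F)F)nn1C)c1nc(-c2ccnc(N(C)C)c2)no1` gives 3.9, the higher of the two numbers and clearly apart from compound 1. The next compound to be measured is compound 3 `COc1cc(-c2noc([C@H](C)NC(=O)c3cc(C(F)(F)F)nn3C)n2)cc(C)n1`, which keeps the shared core and alters only the group on it: 2-methoxy-6-methylpyridin-4-yl in place of 2-(dimethylamino)pyridin-4-yl on an aromatic carbon. In words, 2-methoxy-6-methylpyridin-4-yl stands in place of 2-(dimethylamino)pyridin-4-yl on an aromatic carbon. Among the measured compounds shown here, one measured step bears on this change, a number 0.60 log units higher from compound 1 to compound 2 (beyond the scatter), where dimethylamino replaced methyl on an aromatic carbon. That step was modest. For the measured compounds named here, compound 3 carries a methyl group, as compound 1 does, but it also carries a methoxy group, and no measured compound shows what a methoxy group does on this read-out. The step to compound 2 is therefore only a rough guide, and it gives no clear direction for the new change. The expected result is no change at the digits printed from compound 2 to compound 3 (within the scatter), which means no step beyond the scatter. For compound 3 the estimated value is 3.9, with an expected range from 3.4 to 4.3.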

Compound 3, distribution coefficient: 4.4
Estimate against measurement, compound 3: 0.50 log units below; the measured number lies above the stated range.
By their numbers in this assay, from the lowest: compound 1; then compound 2; then compound 3.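

In this assay, the pyridine substitution at this position proved able to move the number well beyond what the dimethylamino group had shown: putting methoxy on the ring of compound 1, with its methyl group kept, gave a number 1.10 log units higher from compound 1 to compound 3 (beyond the scatter) and was the largest step seen so far. Exchanging 2-(dimethylamino)pyridin-4-yl for 2-methoxy-6-methylpyridin-4-yl gave a number 0.50 log units higher from compound 2 to compound 3 (beyond the scatter) even though the two groups match in heavy atoms, hydrogen-bond donors and hydrogen-bond acceptors, so these counts do not separate them on this assay. Nothing in the available evidence accounts for either step, and the result therefore stands as an observation only.

The exchange from compound 2 to compound 3 alters two ring substituents at once, so the compounds shown do not divide its step into a share for the methoxy group and a share for the methyl group, and a ring carrying methoxy without methyl would be needed to do so. Also open, on these data alone, is what an ethoxy group, a hydroxyl group or a primary amine would give in place of the methoxy group on the same ring.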